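The source may report more compounds than this note shows. Statements on the series, on what has been measured and on what is new or still open speak of the compounds shown alone.

Measured in a functional assay on A549 cells (Homo sapiens) for cytotoxicity, read by MTT assay, with a stated time of 72 h; on this read-out higher numbers stand for weaker inhibition and lower numbers for stronger inhibition:

Compound 1 `O=S(=O)(c1ccccc1)c1nc2ccccc2nc1N1CCCC(O)C1`: 310 nM
Compound 2 `COc1ccc(S(=O)(=O)c2nc3ccccc3nc2N2CCCC(O)C2)cc1`: 2180 nM
Compound 3 `O=S(=O)(c1ccc(F)cc1)c1nc2ccccc2nc1N1CCCC(O)C1`: 8170 nM

Among these three, compound 3 has the highest number, 8170 nM, and so the weakest inhibition. It lies clear of both others: a 26-fold higher number from compound 1 to compound 3 (1.42 log units; beyond the scatter) and a 3.7-fold higher number from compound 2 to compound 3 (0.57 log units; beyond the scatter). The next compound, compound 4 `O=S(=O)(c1ccc(F)cc1)c1nc2ccccc2nc1N1CCC(O)CC1`, keeps everything else in compound 3 but carries 4-hydroxypiperidin-1-yl in place of 3-hydroxypiperidin-1-yl on an aromatic carbon.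

Going by the values given here, no measured step touches this part of the structure, so none gives the size of this change directly. All three steps concern the other aromatic ring. Besides the two above, there is a 7.0-fold higher number from compound 1 to compound 2 (0.85 log units; beyond the scatter). Among the compounds with values here, they show only that a single change elsewhere in these compounds can shift the number well beyond the scatter, so a sizeable step in either direction cannot be ruled out. Compound 3 sits at the top of the three values, which tilts the expectation slightly towards a lower number, though a step beyond the scatter is not specifically expected. The expected step is a 1.6-fold lower number from compound 3 to compound 4 (0.21 log units; within the scatter). For compound 4 the estimated value is 5000 nM, with an expected range from 1500 nM to 16000 nM.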

Compound 4, half-maximal inhibitory concentration: 20200 nM
The estimate for compound 4 lay 4.0-fold (0.61 log units) below the measured number, and the stated range ends below it.
By their numbers in this assay, from the lowest: compound 1; then compound 2; then compound 3; then compound 4.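

In this assay, exchanging 3-hydroxypiperidin-1-yl for 4-hydroxypiperidin-1-yl gives a 2.5-fold higher number from compound 3 to compound 4 (0.39 log units; beyond the scatter), although the two groups have the same atoms and the same counts of hydrogen-bond donors and acceptors. Going by these compounds alone, this is the first reading at this position, on the aromatic carbon next to the ring nitrogen, as all the earlier steps concerned the other aromatic ring, and it shows that the way the atoms of this group are joined is enough on its own to move the number beyond the scatter. Nothing given here accounts for the shift.

Going by these compounds, the change is read in only one setting, with the fluoro group on the other aromatic ring, so it remains open whether the same exchange would shift the number in the same direction in the hydrogen-bearing compound 1 or the methoxy-bearing compound 2. Also open, on these data alone, is how this position would respond to a group other than a hydroxypiperidine, such as an aminopiperidine carrying a primary amine, a morpholine, or a piperidine bearing a carboxylic acid.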